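The source may hold more compounds than are shown below. What is called first, only, known or untested is meant among the compounds shown, and "the series" means these compounds.

In a functional assay on MCF7 cells (Homo sapiens) for cytotoxicity, read by MTT assay, with a stated time of 96 h (a higher number here means a weaker inhibitor, a lower number a stronger inhibitor), compound 2 (`COc1cc(C(=O)c2cn(-c3cccc(N)c3)cc2-c2ccc([N+](=O)[O-])cc2)cc(OC)c1OC`) gives 110 nM, within the scatter of compound 3 (`COc1cc(C(=O)c2cn(-c3cccc(N)c3)cc2-c2cccc(N)c2)cc(OC)c1OC`) at 60 nM. Compound 1 (`COc1cc(C(=O)c2cn(-c3cccc(N)c3)cc2-c2ccccc2F)cc(OC)c1OC`) gives the lower 17 nM, and the gap is a 6.5-fold higher number from compound 1 to compound 2 (0.81 log units; beyond the scatter). Compound 4 (`COc1cc(C(=O)c2cn(-c3ccc(N)cc3)cc2-c2ccc([N+](=O)[O-])cc2)cc(OC)c1OC`) carries 4-aminophenyl in place of 3-aminophenyl on an aromatic nitrogen. Among the measured compounds shown here, no measured step changes this group. The steps of a 3.5-fold higher number from compound 1 to compound 3 (0.55 log units; beyond the scatter) and a 1.8-fold lower number from compound 2 to compound 3 (0.26 log units; within the scatter), like the gap above, change only the aryl group on an aromatic carbon, so they give no size or direction for this change. For the measured compounds named here, with no direct precedent, no step beyond the scatter is expected in this assay, though the uncertainty is wide. The expected change is a 1.1-fold higher number from compound 2 to compound 4 (0.06 log units; within the scatter). The estimate for compound 4 is 125 nM, with an expected range of 35 nM to 450 nM.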

Compound 4, half-maximal inhibitory concentration: 260 nM
For compound 4 the middle estimate is 2.1-fold (0.32 log units) below the measured one; the range from low to high includes it.
By their numbers in this assay, from the lowest: compound 1; then compounds 3 and 2 (each within the scatter of the next); then compound 4.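

Among the compounds shown here, the first measured change on the aromatic nitrogen, 4-aminophenyl in place of 3-aminophenyl, gives in this assay a 2.4-fold higher number from compound 2 to compound 4 (0.37 log units; beyond the scatter) and so shows that this position responds to where the amino group sits on the ring. The reading rests on one pair, both members carrying 4-nitrophenyl. Nothing measured here accounts for the step.

From the compounds shown here alone, whether the same change holds with the 2-fluorophenyl group of compound 1 remains open. Also open, going by these compounds, is how a 3-hydroxyphenyl or 3-methoxyphenyl group on this nitrogen would compare.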